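Para-substituent variation on a diiodosalicylaldehyde hydrazone series

The source may report more compounds than this note shows. Statements on the series, on what has been measured and on what is new or still open speak of the compounds shown alone.

Measured so far:
Compound 1, `COc1ccc(C(=O)N/N=C/c2cc(I)cc(I)c2O)cc1`: 45200 nM
Compound 2, `O=C(N/N=C/c1cc(I)cc(I)c1O)c1ccc(F)cc1`: 12100 nM

Both values come from a functional assay on HepG2 cells (Homo sapiens) for cytotoxicity, with a stated time of 24 h; on this read-out higher numbers stand for weaker inhibition and lower numbers for stronger inhibition. Going by the values given here, compound 2 holds the lowest of the two numbers; its nearest neighbour is compound 1, and the single step connecting them, a 3.7-fold lower number from compound 1 to compound 2 (0.57 log units; beyond the scatter), is modest but lies beyond the scatter. That step is the only one available and it concerns the same position on the same ring that is varied next.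

Compound 3, `O=C(N/N=C/c1cc(I)cc(I)c1O)c1ccc([N+](=O)[O-])cc1`, is not yet measured. It differs from compound 2 by nitro in place of fluoro on an aromatic carbon. Among the compounds with values here, no measured pair shows a nitro entering anywhere, so the step from compound 2 to compound 3 has no direct precedent; the one relevant observation is that exchanging the group at this position in the step from compound 1 to compound 2 moved the number by a modest amount. A change of similar size is therefore plausible, in either direction, and nothing in the data fixes the direction. The working estimate for compound 3 is 9000 nM, with a range of 3000 nM to 30000 nM, which is expected to correspond to a 1.3-fold lower number from compound 2 to compound 3 (0.13 log units; within the scatter).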

Compound 3, half-maximal inhibitory concentration: 24700 nM
Compound 3: middle estimate off by 2.7-fold (0.44 log units), on the low side; low and high end bracket the measured number.
By their numbers in this assay, from the lowest: compound 2; then compounds 3 and 1 (each within the scatter of the next).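

Nitro in place of fluoro on this aromatic carbon gives a 2.0-fold higher number from compound 2 to compound 3 (0.31 log units; beyond the scatter) in this assay, so compound 2 keeps the lowest number of the three, with its steps to both others beyond the scatter. Nitro in place of methoxy gives a 1.8-fold lower number from compound 1 to compound 3 (0.26 log units; within the scatter), so these two groups cannot be told apart at this position, and among the three groups seen here only fluoro stands apart. No evidence on hand accounts for this ordering.

As far as these compounds go, it remains open whether any other group at this position, such as a chloro, an amine, a carboxylic acid or a longer chain, would give a lower number than compound 2 or would fall with compound 1 and compound 3. Also open is whether the same ordering of fluoro, nitro and methoxy would hold if the iodo atoms on the other aromatic ring of the shared core were exchanged for other groups, or in any read-out other than this assay as a measure of these compounds.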